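The source may report more compounds than this note shows. Statements on the series, on what has been measured and on what is new or still open speak of the compounds shown alone.

Measured so far:
Compound 1 `CC(=NNC(=S)Nc1ccccc1F)c1ccccn1`: 5 nM
Compound 2 `C/C(=N\NC(=S)Nc1cccc(F)c1)c1ccccn1`: 18 nM
Compound 3 `CC(=NNC(=S)Nc1cccc(F)c1)c1ccccn1`: 18 nM

In a functional assay on U-87MG ATCC cells (Homo sapiens) for cytotoxicity, read by MTT assay, with a stated time of 48 h (on this read-out lower numbers stand for stronger inhibition and higher numbers for weaker inhibition), compound 2 gives 18 nM, level with compound 3 at 18 nM. These two share the highest number of the three, while compound 1 sits lower at 5 nM, a gap beyond the scatter.

The next compound is compound 4 `C/C(=N\NC(=S)Nc1cccc(I)c1)c1ccccn1`, with iodo in place of fluoro on an aromatic carbon.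

Among the compounds with values here, only one step has been measured between compounds differing in one place, no change at the digits printed from compound 2 to compound 3 (within the scatter). Within the data shown here, it concerns (the fact that one of compounds 2 and 3 is drawn with a defined configuration and the other without, at the place where they differ), so it says nothing about exchanging one halogen for another, and no measured step covers that swap. Among the measured compounds shown here, the only guide is the narrow span of the series, from compound 1 at 5 nM to compound 2 at 18 nM, so no large change is expected, and the direction remains open. The expected change is a 1.2-fold lower number from compound 2 to compound 4 (0.08 log units; within the scatter), which stays within the scatter. For compound 4 the estimated value is 15 nM, with an expected range from 4 nM to 60 nM.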

Compound 4, half-maximal inhibitory concentration: 84 nM
Compound 4: the middle estimate sits 5.6-fold (0.75 log units) below what was measured; measured number above the stated range.
By their numbers in this assay, from the lowest: compound 1; then compounds 2 and 3 (each within the scatter of the next); then compound 4.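

In this assay, the number rises by a 4.7-fold higher number from compound 2 to compound 4 (0.67 log units; beyond the scatter) when iodo replaces fluoro on the aromatic carbon. This shows that the substituent at this place matters: with the rest of the molecule unchanged, iodo goes with weaker inhibition than fluoro. Within the data shown here, the only earlier step, showing no change at the digits printed from compound 2 to compound 3 (within the scatter) as the drawn configuration of a double bond changes, left this substituent untouched and so could not reveal this.

No information given here bears on why the exchange of fluoro for iodo raises the number. On these data alone, whether chloro or bromo at this place would fall between compound 2 and compound 4, and how a non-halogen group such as methoxy or an amine would compare with either, remains open.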